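The compounds below may be only part of what the source reports. "The series", "measured", "known", "first", "only" and "open" are said of these compounds alone.

Of the compounds shown here, two of a shared core have been measured in a functional assay on Raji cells (Homo sapiens) for antiproliferative activity, read by CCK-8 assay, with a stated time of 24 h; on this read-out higher numbers stand for weaker inhibition and lower numbers for stronger inhibition. Compound 1 `C=CC(=O)Nc1cccc(Nc2ncnc(Nc3ccc(-c4cccnc4)cc3)n2)c1` gives 12400 nM in this assay, and compound 2 `C=CC(=O)Nc1cccc(Nc2nc(Cl)nc(Nc3ccc(Oc4ccccc4)cc3)n2)c1` gives 15700 nM. Of the two numbers shown, compound 1 carries the smaller one, but compound 2 sits within the usual scatter of it, so no order between them can be claimed; neither compound inhibits the growth of the Raji cells strongly.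

Compound 3 `C=CC(=O)Nc1cccc(Nc2ncnc(Nc3ccc(C(=O)Nc4ccc(C)cn4)cc3)n2)c1` has not yet been measured in this assay. It departs from compound 1 by one change: (5-methylpyridin-2-yl)carbamoyl in place of pyridin-3-yl on an aromatic carbon. Going by the values given here, no pair of measured compounds shows what such an exchange does here, so its effect on the half-maximal inhibitory concentration cannot be read from the data at hand, and any expectation rests on compound 1 alone. The step of a 1.8-fold lower number from compound 1 to compound 3 (0.25 log units; within the scatter) is expected to be modest and directed toward stronger inhibition, though an outcome within the scatter of compound 1 would not surprise. Compound 3 is therefore estimated at 7000 nM, with a range from 1500 nM to 30000 nM.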

Compound 3, half-maximal inhibitory concentration: 125000 nM
Compound 3: the middle estimate sits 18-fold (1.25 log units) below what was measured; measured number above the stated range.
By their numbers in this assay, from the lowest: compounds 1 and 2 (each within the scatter of the next); then compound 3.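

At the place para to a large group, on the six-membered aromatic ring of carbon only, putting (5-methylpyridin-2-yl)carbamoyl in place of pyridin-3-yl gives in this assay a 10-fold higher number from compound 1 to compound 3 (1.00 log units; beyond the scatter), a step beyond the scatter and toward weaker inhibition. Going by these compounds alone, this is the first step that differs in one place only, since compound 1 and compound 2 differ in more than one place and could not show how this position responds to what it carries; it now shows that the position does not accept every substituent alike, and that the larger group, with its carbonyl and amide hydrogen, goes with the weaker result. Nothing at hand bears on why the number rises.

The single step changes the linking carbamoyl and the ring together, so the compounds shown leave open which of the two goes with the rise, and whether a primary carboxamide, an unsubstituted pyridin-2-yl carbamoyl or a carboxylic acid at this position would behave in the same way. They also leave open what a chlorine on the core of compound 1 would do on its own.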